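Ester chain variation, compound 4 pending

A few compounds are considered here, and "the series" means these few. Any claim that something is new, unique, unknown or untested is made for them only; others in the source may bear on it.

Measured so far:
compound 1 `COc1cc(/C=C/C(=O)OCCc2cccc(C)c2)cc(OC)c1O` — 200 nM
compound 2 `COc1cccc(CCOC(=O)/C=C/c2cc(OC)c(O)c(OC)c2)c1` — 210 nM
compound 3 `COc1ccccc1CCOC(=O)/C=C/c1cc(OC)c(O)c(OC)c1` — 250 nM

The shared core is carried through; the three compounds differ only in the group on the saturated chain carbon two bonds along the chain from the oxygen next to the carbonyl group. In an assay on PMNL cells for inhibition of Polyunsaturated fatty acid 5-lipoxygenase (Homo sapiens), read by HPLC, with stated times of 5 min and 15 min (a lower number here means a stronger inhibitor, a higher number a weaker inhibitor), compound 1 gives 200 nM, compound 2 gives 210 nM and compound 3 gives 250 nM. Compound 3 has the highest of the three numbers, but a 1.3-fold higher number from compound 1 to compound 3 (0.10 log units; within the scatter) and a 1.2-fold higher number from compound 2 to compound 3 (0.08 log units; within the scatter) both stay within the scatter, as does a 1.1-fold higher number from compound 1 to compound 2 (0.02 log units; within the scatter); on these numbers the three are not distinguishable.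

Compound 4 `CCCOC(=O)/C=C/c1cc(OC)c(O)c(OC)c1` differs from compound 3 by methyl in place of 2-methoxyphenyl on a saturated chain carbon, two bonds along the chain from an oxygen next to a carbonyl group. Among the measured compounds shown here, each measured step swaps one aromatic group for another at this place; none removes the ring altogether, so no measured step bears directly on this change. From the compounds shown here alone, the aryl swaps moved nothing beyond the scatter, which argues against a large step, but the loss of the ring is untested here. A modest rise, if any, is expected, with a wide range. For compound 4 the expected step in this assay is a 1.4-fold higher number from compound 3 to compound 4 (0.15 log units; within the scatter). Compound 4 is accordingly estimated at 350 nM, within 120 nM to 1100 nM.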

Compound 4, half-maximal inhibitory concentration: 710 nM
The estimate for compound 4 lay 2.0-fold (0.31 log units) below the measured number; the range from low to high includes it.
By their numbers in this assay, from the lowest: compounds 1, 2 and 3 (each within the scatter of the next); then compound 4.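

In this assay, among the compounds shown here, methyl in place of the aromatic group is the first change at this saturated chain carbon to go beyond the scatter: a 2.8-fold higher number from compound 3 to compound 4 (0.45 log units; beyond the scatter), with a 3.4-fold higher number from compound 2 to compound 4 (0.53 log units; beyond the scatter) and a 3.6-fold higher number from compound 1 to compound 4 (0.55 log units; beyond the scatter). The place is therefore not indifferent to what it carries: compound 1, compound 2 and compound 3, which cannot be told apart, all keep a six-membered aromatic ring there, and compound 4, the only one without it, has the highest number, with no listed compound going against this split. All three steps are modest, and no measurement at hand gives a reason for them.

The compounds shown do not separate the loss of the aromatic ring from the simple loss of heavy atoms at this place, a distinction that an unsubstituted phenyl, a cyclohexyl or a longer chain would help to draw. Also open, from the compounds shown here alone, is how this place responds to a ring carrying an amine or a carboxylic acid, since only methyl and methoxy on the ring appear here.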